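A few compounds are considered here, and "the series" means these few. Any claim that something is new, unique, unknown or untested is made for them only; others in the source may bear on it.

Compound 2 `Cc1ccc(-c2nnc(CNC(=O)CN)o2)cc1` was tested in an assay for inhibition of histone deacetylase 8 (Homo sapiens), read by fluorescence, with a stated time of 15 min (a higher number here means a weaker inhibitor, a lower number a stronger inhibitor), where compound 2 gives 139 nM. Compound 1 `C[C@@H](N)C(=O)NCc1nnc(-c2ccc(F)cc2)o1`, which differs from it in several places at once, gives 116 nM in this assay, a number that lies within the usual scatter of the value of compound 2, so the two cannot be told apart on these data. Compound 3 `Cc1ccc(-c2nnc(CNC(=O)[C@@H](C)N)o2)cc1` has not been measured. It differs from compound 2 by methyl in place of hydrogen on a saturated chain carbon bound to an amine nitrogen and a carbonyl carbon. For the measured compounds named here, no measured pair isolates this change on its own. Compound 1 does carry the 1-aminoethyl chain that enters here, and because compound 1 gives 116 nM in this assay, no step beyond the scatter is expected from the added methyl. Compound 3 is therefore expected to give about 115 nM in this assay, with a range from 50 nM to 260 nM, an expected step of a 1.2-fold lower number from compound 2 to compound 3 (0.08 log units; within the scatter) that should stay within the scatter.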

Compound 3, half-maximal inhibitory concentration: 121 nM
Estimate against measurement, compound 3: 1.1-fold (0.02 log units) below, within the range that was stated.
By their numbers in this assay, from the lowest: compounds 1, 3 and 2 (each within the scatter of the next).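

In this assay, for the compounds shown here, the step for methyl in place of hydrogen on a saturated chain carbon bound to an amine nitrogen and a carbonyl carbon is isolated for the first time (a 1.1-fold lower number from compound 2 to compound 3 (0.06 log units; within the scatter)), and it shows that this position accepts the methyl without a change beyond the scatter. With the 1-aminoethyl chain held constant, methyl in place of fluoro on an aromatic carbon also stays within the scatter (a 1.0-fold higher number from compound 1 to compound 3 (0.02 log units; within the scatter)), so neither change separates these compounds in this measurement. Nothing available explains why either change leaves the number within the scatter.

The compounds shown leave open whether an ethyl group or a longer chain on that same saturated carbon would also stay within the scatter. They also leave open how a chloro or a methoxy group would read on the aromatic carbon.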